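This account rests on a few compounds, and the source may have more. Where it says the series, first, only, none or still open, it means among the compounds named here.

Measured so far in a functional assay on MCF7 cells (Homo sapiens) for inhibition, read by MTT assay, with a stated time of 72 h; a lower number here means a stronger inhibitor, a higher number a weaker inhibitor:
compound 1 `C#CCSc1nc(Nc2ccc(OC)cc2)c(C#N)c(-c2ccccc2)n1` gives 35600 nM;
compound 2 `C#CCSc1nc(Nc2cccc(C(F)(F)F)c2)c(C#N)c(-c2ccccc2)n1` gives only a limit of the assay, > 128000 nM;
compound 3 `COc1ccc(Nc2nc(SCc3cn(Cc4ccccc4Cl)nn3)nc(-c3ccccc3)c2C#N)cc1` gives 8050 nM.

Compound 3 stands lowest of the two numbers in this assay, with compound 1 giving a larger number, beyond the scatter. Compound 4 `N#Cc1c(Nc2cccc(C(F)(F)F)c2)nc(SCc2cn(Cc3ccccc3Cl)nn2)nc1-c1ccccc1` differs from compound 3 by 3-(trifluoromethyl)phenyl in place of 4-methoxyphenyl on a nitrogen on an aromatic ring. The same exchange separates compound 1 from compound 2. Compound 2 reaches only a limit in this assay. Among the compounds with values here, no measured step covers the exchange, so the expectation rests on that pair alone: the exchange is expected to weaken inhibition in this assay, by a 5.0-fold higher number from compound 3 to compound 4 (0.70 log units; beyond the scatter). Compound 4 may also reach only a limit. Compound 4 is expected to give 40000 nM, between 12000 nM and 128000 nM.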

Compound 4, half-maximal inhibitory concentration: 12600 nM
For compound 4 the middle estimate is 3.2-fold (0.50 log units) above the measured one; the range from low to high includes it.
By their numbers in this assay, from the lowest: compounds 3 and 4 (each within the scatter of the next); then compound 1. At a limit, above all of these: compound 2.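

In this assay, putting 3-(trifluoromethyl)phenyl in place of 4-methoxyphenyl on the nitrogen gives a 1.6-fold higher number from compound 3 to compound 4 (0.19 log units; within the scatter), so on the core of compound 3 this exchange brings no readable change. The earlier pair could not give a size for the same exchange, as compound 2 gives only a limit of the assay: the limit of > 128000 nM in this assay, at which 1 of the 4 values shown sits.

What the compounds shown leave open is how this position responds to a group other than a substituted phenyl ring, such as a simple amine or a longer carbon chain. On these data alone, whether a phenyl ring carrying a carboxylic acid would fit the same picture also stays open.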